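Double-bond aryl swap in the lactone series: compound 4

The source may report more compounds than this note shows. Statements on the series, on what has been measured and on what is new or still open speak of the compounds shown alone.

Measured so far in an assay for displacement of a labelled ligand from protein kinase C delta type (Mus musculus), with a stated time of 30 min, in the presence of a further agent that is not named here; on this read-out higher numbers stand for weaker binding and lower numbers for tighter binding:
compound 1, `CC(C)(C)C(=O)OCC1(CO)C/C(=C\c2ccc(C(=O)O)cc2)C(=O)O1`: 1070 nM
compound 2, `CC(C)C(CC(=O)OCC1(CO)C/C(=C\c2ccc(C(=O)O)cc2)C(=O)O1)C(C)C`: 560 nM
compound 3, `CC(C)C(CC(=O)OCC1(CO)C/C(=C/c2ccc(C(=O)O)cc2)C(=O)O1)C(C)C`: 865 nM

Compound 2 gives the lowest of the three numbers, yet neither neighbour is separated from it beyond the scatter: a 1.9-fold lower number from compound 1 to compound 2 (0.28 log units; within the scatter) and a 1.5-fold higher number from compound 2 to compound 3 (0.19 log units; within the scatter). Compound 3 differs from compound 2 only in how a double bond is drawn, (the fact that one of compounds 2 and 3 is drawn with a defined configuration and the other without, at the place where they differ), so the series gives no cause for that small shift.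

Compound 4, `CC(C)C(CC(=O)OCC1(CO)C/C(=C\c2cccc(O)c2)C(=O)O1)C(C)C`, is not yet measured. It differs from compound 2 by 3-hydroxyphenyl in place of 4-carboxyphenyl on a double-bonded chain carbon bound to a double-bonded ring carbon. Among the measured compounds shown here, no measured step touches this part of the molecule; the two known steps concern the ester group and the double-bond geometry, and both stayed within the scatter. Expectation for this assay therefore rests on no direct precedent, and a step of a 1.4-fold higher number from compound 2 to compound 4 (0.15 log units; within the scatter) of uncertain direction is expected, with wide bounds. Compound 4 is estimated at 800 nM, between 200 nM and 3200 nM.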

Compound 4, dissociation constant: 2.46 nM
Estimate against measurement, compound 4: 330-fold (2.51 log units) above; measured number below the stated range.
By their numbers in this assay, from the lowest: compound 4; then compounds 2, 3 and 1 (each within the scatter of the next).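

Among the compounds shown here, the aryl group on the double-bonded chain carbon is the first place where a change moves the number beyond the scatter in this assay: a 230-fold lower number from compound 2 to compound 4 (2.36 log units; beyond the scatter). The ester and double-bond steps gave no sign of this sensitivity. The swap replaces 4-carboxyphenyl with 3-hydroxyphenyl in a single step, and nothing shown gives a cause for the gain.

Open, going by these compounds, is which part of the swap carries the gain: a plain phenyl, or an amine or methoxy group in place of the hydroxyl, would help separate them. Also open, on these data alone, is whether the gain holds with the tert-butyl ester or the other double-bond geometry.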